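A few compounds are considered here, and "the series" means these few. Any claim that something is new, unique, unknown or untested is made for them only; others in the source may bear on it.

In a functional assay on HeLa cells (Homo sapiens) for inhibition, read by CCK-8 assay, with a stated time of 72 h (on this read-out lower numbers stand for stronger inhibition and higher numbers for weaker inhibition), compound 1 (`O=C(/C=C/c1cccnc1)NCCCCCc1ccc(S(=O)(=O)Nc2ccccc2)cc1`) gives 333 nM and compound 2 (`O=C(/C=C/c1cccnc1)NCCCCCCCc1ccc(S(=O)(=O)Nc2ccccc2)cc1`) gives 223 nM as two values within the scatter of each other. Compound 3 (`O=C(/C=C/c1cccnc1)NCCCCCCc1cccc(S(=O)(=O)Nc2ccccc2)c1`) gives 30.4 nM as the lowest of the three numbers, and its gaps to compound 2 and to compound 1 both lie beyond the scatter.

The next compound to read is compound 4 (`Cc1ccc(NS(=O)(=O)c2cccc(CCCCCCNC(=O)/C=C/c3cccnc3)c2)cc1`), which departs from compound 3 by one change (methyl in place of hydrogen on an aromatic carbon). This is methyl in place of hydrogen on an aromatic carbon, para to a large group, so that phenyl becomes 4-methylphenyl. Within the data shown here, all three measured compounds carry the same plain anilino group, so the series holds no measured step for this change, and no direction can be read from the data.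

The expectation is therefore a step no larger than the scatter, with a slight lean toward a higher number, since compound 3 at 30.4 nM already holds the lowest value. The estimated step of a 1.3-fold higher number from compound 3 to compound 4 (0.12 log units; within the scatter) is expected to stay within the scatter. For compound 4 the expected value is 40 nM as the central estimate. The estimated range for compound 4 runs from 14 nM to 115 nM on present evidence.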

Compound 4, half-maximal inhibitory concentration: 38.8 nM
Compound 4: the middle estimate sits 1.0-fold (0.01 log units) above what was measured, and the stated range covers the measured number.
By their numbers in this assay, from the lowest: compounds 3 and 4 (each within the scatter of the next); then compounds 2 and 1 (each within the scatter of the next).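

In this assay, among these compounds, the only step available for this position, a 1.3-fold higher number from compound 3 to compound 4 (0.11 log units; within the scatter), lies within the scatter, so the numbers for the two compounds cannot be told apart. The earlier compounds shown here all carried the plain anilino group, and this pair now shows that phenyl to 4-methylphenyl, with one added carbon and no added hydrogen-bond donor or acceptor, gives no readable shift at this site on the shared core. No measured property of either compound bears on this result, so the data offer no explanation for it.

On these data alone, a single methyl says little about how far this position tolerates change, and it remains open whether a larger group such as tert-butyl, a halogen such as chlorine, or a charged or ionisable group such as a carboxylic acid or an amine would also stay within the scatter. As far as these compounds go, it also remains open whether the same methyl would give a similar step on the cores of compound 1 and compound 2, which have different chain lengths and a different substitution pattern.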